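Trimethoxyphenyl pyrazole chalcones: predicting a fourth analogue

A few compounds are considered here, and "the series" means these few. Any claim that something is new, unique, unknown or untested is made for them only; others in the source may bear on it.

Measured compounds:
- Compound 1, `COc1cc(-c2cc(/C=C/C(=O)c3ccc(N)cc3)[nH]n2)cc(OC)c1OC`: 15%
- Compound 2, `COc1ccc(C(=O)/C=C/c2cc(-c3cc(OC)c(OC)c(OC)c3)n[nH]2)cc1OC`: 10%
- Compound 3, `COc1ccc(-c2cc(/C=C/C(=O)c3ccc(N)cc3)[nH]n2)cc1OC`: 37%

All three compounds were tested in a functional assay on NCI/ADR-RES cells (Homo sapiens) for cytotoxicity, read by sulforhodamine B assay, with a stated time of 48 h, tested at 10 uM; on this read-out higher numbers stand for a weaker effect at the one concentration tested and lower numbers for a stronger effect. Compound 3 gives 37%, compound 1 gives 15%, and compound 2 gives 10%. Compound 1 and compound 3 share a core; compound 1 carries one change on it, (methoxy in place of hydrogen on an aromatic carbon), and the result in this assay is a number 22 percentage points lower from compound 3 to compound 1 (beyond the scatter). Compound 2 is built on a different core, and the difference between the two cores is not broken down here. Compound 1 and compound 2 differ in one place on the carbonyl side, and that step, a number 5 percentage points lower from compound 1 to compound 2 (within the scatter), is within the scatter, so no order between the two can be read from it.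

Compound 4, `COc1cc(C(=O)/C=C/c2cc(-c3cc(OC)c(OC)c(OC)c3)n[nH]2)cc(OC)c1OC`, has not been measured. Within the data shown here, it is related to compound 2 by methoxy in place of hydrogen on an aromatic carbon, the same change as the one that carries compound 3 to compound 1. Because compound 3 to compound 1 gave a number 22 percentage points lower from compound 3 to compound 1 (beyond the scatter), a step of similar direction is expected from compound 2 to compound 4 in this assay, estimated as a number 4 percentage points lower from compound 2 to compound 4 (within the scatter). The step is expected to be smaller only since compound 2, at 10%, is already close to the bottom of what the read-out can show. The estimate for compound 4 in this assay is 6%, with a range from -4% to 17%.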

Compound 4, a percentage reported as activity, at one concentration (the size of the read-out at that concentration, not a potency): 12%
Compound 4: middle estimate off by 6 percentage points, on the low side; low and high end bracket the measured number.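

In this assay, putting methoxy in place of hydrogen on the carbonyl-side aromatic ring gives a number 2 percentage points higher from compound 2 to compound 4 (within the scatter), so this step shows no change that can be read. Set beside the earlier case, the same swap of hydrogen for methoxy does not carry over from one core to the other with the same result: the same change on two cores in this assay, a number 22 percentage points lower (beyond the scatter) from compound 3 to compound 1 and a number 2 percentage points higher (within the scatter) from compound 2 to compound 4, 24 percentage points apart, beyond the scatter of two such steps This shows that the large drop seen on the first core cannot be assumed for the second, but two pairs do not show why the steps differ or what the change would do on a third core, and compound 2, at 10%, already lies near the low end of the read-out, so a further drop would be hard to see there.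

The compounds shown leave open how other groups would read at this same place on the ring, such as a hydroxyl group, a chlorine atom or a longer ethoxy chain in place of the methoxy. They also leave open whether the pattern in this assay would hold across a wider set of matched pairs, which would be needed before calling the effect of this change dependent on the core.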